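Methoxy added to the phenyl of compound 2

A few compounds are considered here, and "the series" means these few. Any claim that something is new, unique, unknown or untested is made for them only; others in the source may bear on it.

Measured so far:
compound 1, `CC(C)CC1C(=O)N(C)c2cnc(Nc3ccc(S(N)(=O)=O)cc3)nc2N1C`, 77 nM
compound 2, `CN1C(=O)C(c2ccccc2)N(C)c2nc(Nc3ccc(S(N)(=O)=O)cc3)ncc21`, 383 nM

In an assay on Sf9 cells for inhibition of serine/threonine-protein kinase 4 (Homo sapiens), read by luminescence and ADP-Glo, with a stated time of 1 h, in the presence of a further agent that is not named here (on this read-out lower numbers stand for stronger inhibition and higher numbers for weaker inhibition), compound 1 gives 77 nM, while compound 2 gives 383 nM. Going by the values given here, the single step between them, a 5.0-fold higher number from compound 1 to compound 2 (0.70 log units; beyond the scatter), is the only one that has been measured. Among the compounds with values here, compound 2 therefore stands highest of the two numbers in this assay, with compound 1 as its sole neighbour, separated by a step beyond the scatter.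

Compound 3, `COc1cccc(C2C(=O)N(C)c3cnc(Nc4ccc(S(N)(=O)=O)cc4)nc3N2C)c1`, differs from compound 2 by methoxy in place of hydrogen on an aromatic carbon. Within the data shown here, no measured step touches this place: the one step in hand, a 5.0-fold higher number from compound 1 to compound 2 (0.70 log units; beyond the scatter), exchanges the whole group on the saturated ring carbon and says nothing about a substituent on the phenyl itself. Among the measured compounds shown here, with no pair showing the effect of a methoxy on that ring, the expectation for compound 3 rests on compound 2 alone, and no step beyond the scatter is expected in this assay: a 1.1-fold lower number from compound 2 to compound 3 (0.04 log units; within the scatter).

Compound 3 is thus estimated at 350 nM in this assay, with a range from 120 nM to 1100 nM.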

Compound 3, half-maximal inhibitory concentration: 954 nM
Compound 3: middle estimate off by 2.7-fold (0.44 log units), on the low side; measured number inside the range.
By their numbers in this assay, from the lowest: compound 1; then compound 2; then compound 3.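

In this assay, the phenyl on the saturated ring carbon proves sensitive to substitution: this first measured change on the ring itself, methoxy in place of hydrogen on an aromatic carbon, gives a 2.5-fold higher number from compound 2 to compound 3 (0.40 log units; beyond the scatter). Against isobutyl on the same saturated ring carbon, 3-methoxyphenyl gives a 12-fold higher number from compound 1 to compound 3 (1.09 log units; beyond the scatter), a larger step than the one for unsubstituted phenyl, a 5.0-fold higher number from compound 1 to compound 2 (0.70 log units; beyond the scatter), so across these three compounds the number rises from isobutyl through phenyl to 3-methoxyphenyl. Nothing available on these compounds accounts for the rise on adding methoxy.

Going by these compounds, it remains open whether this rise is specific to methoxy or would also follow from another group at the same place on the ring, such as a hydroxyl, a fluorine or an amine, and whether methoxy on another carbon of the phenyl would give a similar step. Also open, on these data alone, is whether another saturated group in place of isobutyl on the saturated ring carbon, such as a longer chain or cyclohexyl, would give a number lower than that of compound 1.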